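Piperidin-1-yl to 2-oxopyrrolidin-1-yl: a step back toward the limit

The source may report more compounds than this note shows. Statements on the series, on what has been measured and on what is new or still open speak of the compounds shown alone.

Measured so far:
compound 1, `COc1cc2nc(NCc3ccccc3)nc(NC3CCCCCC3)c2cc1OC`: < 0%, a limit of the assay rather than a number
compound 2, `CCNc1nc(N2CCC(N3CCCC3)CC2)nc2cc(OC)c(OC)cc12`: < 0%, again a limit rather than a number
compound 3, `COc1cc2nc(NCCN3CCCCC3)nc(NC3CCCCCC3)c2cc1OC`: 18%

For the measured compounds named here, in an in vitro assay on B300-19 cells for displacement of a labelled ligand from C-C chemokine receptor type 4 (Homo sapiens), tested at 1 uM (a lower number here means less inhibition, a higher number more inhibition at the concentration tested (going by the name of the read-out)), compound 3 stands as the only genuine number among the three values; the other two sit at the limit of < 0% in this assay, at which 2 of the 3 values shown sit. Going by the values given here, the one measured step that bears on the new compound is a number at least 18 percentage points higher from compound 1 to compound 3 (beyond the scatter), and it shows that the piperidin-1-yl-bearing chain is what lifts compound 3 off that limit.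

Compound 4 is `COc1cc2nc(NCCCN3CCCC3=O)nc(NC3CCCCCC3)c2cc1OC`. Its change from compound 3 is (2-oxopyrrolidin-1-yl)methyl in place of piperidin-1-yl on a saturated chain carbon, two bonds along the chain from a nitrogen on an aromatic ring. This removes the very group whose arrival gave the only measured gain, and puts in its place a ring that carries a carbonyl instead. Nothing measured here tells how the 2-oxopyrrolidin-1-yl fares, so the expectation leans on the step just named.

The expected step is a number 15 percentage points lower from compound 3 to compound 4 (beyond the scatter), a return toward the limit. Compound 4 is therefore expected to give about 3%, with a range from -12% to 18%.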

Compound 4, a percentage reported as inhibition, at one concentration (the size of the read-out at that concentration, not a potency): 8%
Compound 4: middle estimate off by 5 percentage points, on the low side; measured number inside the range.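

In this assay, replacing the 2-(piperidin-1-yl)ethyl chain with 3-(2-oxopyrrolidin-1-yl)propyl gives a number 10 percentage points lower from compound 3 to compound 4 (within the scatter), so these two side chains cannot be told apart at this position, and the piperidin-1-yl group is not shown to be required. Set against the side chain that ends in phenyl, the change gives a number at least 8 percentage points higher from compound 1 to compound 4 (that floor lies within the scatter), so the gain for the 3-(2-oxopyrrolidin-1-yl)propyl chain is not established. Compound 1 stands at a limit of the assay and not at a number: the limit of < 0% in this assay, at which 2 of the 4 values shown sit.

The step changes the ring and the chain together, so the compounds shown do not separate the contribution of either. They also leave open whether a morpholine, a primary amine or a carboxylic acid at the end of the chain would move the inhibition beyond the scatter.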